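Compound 4: trifluoromethoxy in place of dimethylamino

The compounds below may be only part of what the source reports. "The series", "measured", "known", "first", "only" and "open" are said of these compounds alone.

In an ADME assay for permeability, using PAMPA, at pH 7.4 (on this read-out lower numbers stand for lower permeability and higher numbers for higher permeability), compound 1 `Cc1cc(NC(=O)Nc2ccc(C(C)(C)C)cc2)c2ccccc2n1` gives 142 10^-6 cm/s and compound 3 `Cc1cc(NC(=O)Nc2cnc3ccccc3c2)c2ccccc2n1` gives 46 10^-6 cm/s while compound 2 `Cc1cc(NC(=O)Nc2ccc(N(C)C)cc2)c2ccccc2n1` gives 2 10^-6 cm/s as the lowest of the three numbers. Compound 4 `Cc1cc(NC(=O)Nc2ccc(OC(F)(F)F)cc2)c2ccccc2n1` carries trifluoromethoxy in place of dimethylamino on an aromatic carbon and remains unmeasured. Going by the values given here, one measured step bears on this change, dimethylamino in place of tert-butyl on an aromatic carbon, which gave a 71-fold lower number from compound 1 to compound 2 (1.85 log units; beyond the scatter) and lies beyond the scatter. Read in reverse, it points upward for the loss of dimethylamino, although no measured compound carries trifluoromethoxy. A large upward step is therefore expected, estimated as a 45-fold higher number from compound 2 to compound 4 (1.65 log units; beyond the scatter) and beyond the scatter. For compound 4 the estimated value is 90 10^-6 cm/s (range 30 10^-6 cm/s to 250 10^-6 cm/s).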

Compound 4, apparent permeability: 531 10^-6 cm/s
Compound 4: the middle estimate sits 5.9-fold (0.77 log units) below what was measured, and the stated range ends below it.
By their numbers in this assay, from the lowest: compound 2; then compound 3; then compound 1; then compound 4.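

In this assay, going by these compounds alone, the place para to a large group now spans a wider range than the earlier compounds showed: trifluoromethoxy in place of dimethylamino gives a 270-fold higher number from compound 2 to compound 4 (2.42 log units; beyond the scatter). Trifluoromethoxy also exceeds tert-butyl at this place, with a 3.7-fold higher number from compound 1 to compound 4 (0.57 log units; beyond the scatter), so tert-butyl no longer marks the top of the series. Nothing shown here explains either step. The compounds shown leave open where a trifluoromethyl, a methoxy or a chlorine would stand against trifluoromethoxy and tert-butyl. They also leave open whether a primary amine would sit as low as dimethylamino.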